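The source may report more compounds than this note shows. Statements on the series, on what has been measured and on what is new or still open speak of the compounds shown alone.

Measured so far:
compound 1, `COc1cc2c(Oc3ccc(NC(=O)N/N=C/c4ccc([N+](=O)[O-])cc4)cc3F)ccnc2cc1OCCCN1CCCC1`, 470 nM;
compound 2, `COc1cc2c(Oc3ccc(NC(=O)N/N=C/c4ccc(C(F)(F)F)cc4)cc3F)ccnc2cc1OCCCN1CCCC1`, 1300 nM;
compound 3, `COc1cc2c(Oc3ccc(NC(=O)N/N=C/c4ccc(Cl)cc4Cl)cc3F)ccnc2cc1OCCCN1CCCCC1`, 460 nM.

All three were tested in a functional assay on MKN-45 cells (Homo sapiens) for cytotoxicity, read by MTT assay, with a stated time of 72 h; on this read-out lower numbers stand for stronger inhibition and higher numbers for weaker inhibition. Compound 3 gives the lowest number of the three, though its gap to compound 1 lies within the scatter, so no order between those two can be claimed; only compound 2 stands clearly apart from it.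

Compound 4, `COc1cc2c(Oc3ccc(NC(=O)N/N=C/c4ccc(O)cc4)cc3F)ccnc2cc1OCCCN1CCCCC1`, differs from compound 3 in one place: 4-hydroxyphenyl in place of 2,4-dichlorophenyl on a carbon with a double bond to nitrogen.

For the measured compounds named here, the only single-point step measured, a 2.8-fold higher number from compound 1 to compound 2 (0.44 log units; beyond the scatter), concerns a different exchange on the same phenyl and on a core with a different amine; it shows that changing the group on that phenyl can shift the number modestly. Going by the values given here, no measured step covers the move from a dichlorinated to a hydroxylated phenyl, so the direction of the step in this assay is uncertain. Taking the narrow spread of the three numbers as a guide, a step of modest size toward a higher number, a 1.7-fold higher number from compound 3 to compound 4 (0.24 log units; within the scatter), is expected, and compound 4 is estimated at 800 nM, in the range 250 nM to 3000 nM.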

Compound 4, half-maximal inhibitory concentration: 850 nM
The estimate for compound 4 lay 1.1-fold (0.03 log units) below the measured number, within the range that was stated.
By their numbers in this assay, from the lowest: compounds 3, 1, 4 and 2 (each within the scatter of the next, the first and the last beyond it).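

In this assay the exchange of 2,4-dichlorophenyl for 4-hydroxyphenyl on a carbon with a double bond to nitrogen gives a 1.8-fold higher number from compound 3 to compound 4 (0.27 log units; within the scatter) and so leaves the two compounds indistinguishable. The earlier compounds shown here offered only the exchange of nitro for trifluoromethyl on the core of compound 1; this step shows that, on the core of compound 3, a phenyl with a hydrogen-bond donor and acceptor and no chlorine can take the place of the dichlorinated one with no change beyond the scatter. Nothing measured here accounts for this result.

On these data alone, it remains open whether the same exchange would read alike on the core of compound 1, with its different amine. As far as these compounds go, it is also open whether an amine or a carboxylic acid on the phenyl in place of the hydroxyl would stay within this range.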